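A few compounds are considered here, and "the series" means these few. Any claim that something is new, unique, unknown or untested is made for them only; others in the source may bear on it.

Among the measured compounds shown here, in an ADME assay on microsomes from liver (Homo sapiens) for metabolic stability, read by LC-MS, with a stated time of 30 min (a higher number here means that the compound lasts longer, a lower number that the compound disappears faster), compound 2 `CCc1ccc(N(CC(C)C)S(=O)(=O)c2ccc3c(c2)C(O)CC(C2CCOCC2)O3)cc1` gives 3.7 h, the lowest of the three numbers so far, with compound 3 `O=S(=O)(c1ccc2c(c1)C(O)CC(C1CCOCC1)O2)N1CCCC1c1ccccc1C(F)(F)F` at 7.6 h and compound 1 `CCc1ccc(N(C2CCC2)S(=O)(=O)c2ccc3c(c2)C(O)CC(C2CCOCC2)O3)cc1` at 49 h. Compound 4 `CC(C)CN(c1ccc(C#N)cc1)S(=O)(=O)c1ccc2c(c1)C(O)CC(C1CCOCC1)O2` has cyano in place of ethyl on an aromatic carbon, para to a large group: cyano in place of ethyl on an aromatic carbon. For the measured compounds named here, no measured step covers this swap. The only one, a 13-fold lower number from compound 1 to compound 2 (1.12 log units; beyond the scatter), is isobutyl in place of cyclobutyl on a sulfonamide nitrogen, so it shows how far numbers can move, not the direction here. A moderate rise in this assay is expected, resting only on compound 3, which carries no ethyl and gives 7.6 h. The estimated change is a 1.9-fold higher number from compound 2 to compound 4 (0.28 log units; within the scatter). For compound 4 the estimate is 7 h, with an expected range of 2.5 h to 20 h.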

Compound 4, half-life: 0.8 h
Compound 4: middle estimate off by 8.8-fold (0.94 log units), on the high side, and the stated range ends above it.
By their numbers in this assay, from the lowest: compound 4; then compound 2; then compound 3; then compound 1.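

Moving from 4-ethylphenyl to 4-cyanophenyl gives a 4.6-fold lower number from compound 2 to compound 4 (0.67 log units; beyond the scatter) in this assay, so a change on this aromatic carbon, para to a large group, can lower the number beyond the scatter. Among the compounds shown here, the earlier step covered only the sulfonamide nitrogen, so this is the first reading of this position. No measurement shown accounts for the drop.

On these data alone, whether cyano has a similar effect with cyclobutyl on the sulfonamide nitrogen remains open. As far as these compounds go, how an amine, a carboxylic acid or a longer chain would read at this aromatic carbon also remains open.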